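Trimming a side chain and the tolerance expected

The source may report more compounds than this note shows. Statements on the series, on what has been measured and on what is new or still open speak of the compounds shown alone.

Of the compounds shown here, three sharing one core have been tested in an ADME assay on MDCK cells (Canis lupus familiaris) for cytotoxicity, read by microscopy, with a stated time of 48 h; a lower number here means that less compound is tolerated, a higher number that more compound is tolerated. Compound 1 `CCc1csc(CN[C@@H]2C[C@H]3C[C@@H]([C@H]2C)C3(C)C)c1` gives 25000 nM. Compound 2 `CCCc1csc(CN[C@@H]2C[C@H]3C[C@@H]([C@H]2C)C3(C)C)c1` gives 12500 nM; the step between them is a 2.0-fold lower number from compound 1 to compound 2 (0.30 log units; within the scatter). Compound 3 `C[C@H]1[C@H](NCc2sccc2Br)C[C@H]2C[C@@H]1C2(C)C` gives 50000 nM, a higher number than compound 2, beyond the usual scatter. Compound 2 therefore sits at the low end of the three numbers, within the scatter of compound 1 and clearly apart from compound 3.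

Compound 4 `Cc1csc(CN[C@@H]2C[C@H]3C[C@@H]([C@H]2C)C3(C)C)c1` has not yet been measured. It differs from compound 2 by hydrogen in place of ethyl on a saturated chain carbon bound to an aromatic carbon. For the measured compounds named here, the only measured step that bears on this change is a 2.0-fold lower number from compound 1 to compound 2 (0.30 log units; within the scatter), where one carbon added to the chain went with a small shift, within the scatter. Taking the ethyl away runs the other way and goes further along the chain, so a modest rise in the number is expected, near the edge of the scatter. Compound 4 is expected to give 35000 nM, with a range from 12500 nM to 100000 nM. The expected step is a 2.8-fold higher number from compound 2 to compound 4 (0.45 log units; beyond the scatter).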

Compound 4, minimum cytotoxic concentration: 12500 nM
Beside the measured number, compound 4's estimate is 2.8-fold (0.45 log units) above it, within the range that was stated.
By their numbers in this assay, from the lowest: compounds 2, 4, 1 and 3 (each within the scatter of the next, the first and the last beyond it).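

Going from propyl to methyl on this carbon gives no change at the digits printed from compound 2 to compound 4 (within the scatter) in this assay, so removing an ethyl group from the chain does not separate the two compounds. Compared with the ethyl chain of compound 1, the methyl group gives a 2.0-fold lower number from compound 1 to compound 4 (0.30 log units; within the scatter), so methyl, ethyl and propyl all lie within the scatter of their neighbours in the series and chain length shows no clear trend over this short range. The larger difference appears when the whole aromatic group is exchanged, with 4-methylthiophen-2-yl in place of 3-bromothiophen-2-yl giving a 4.0-fold lower number from compound 3 to compound 4 (0.60 log units; beyond the scatter).

Nothing available explains these numbers. From the compounds shown here alone, it remains open whether a longer chain such as butyl, or an amine or a carboxylic acid at the end of the chain, would move the number beyond the scatter.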